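Amide nitrogen substituent swap on a shared thiadiazole-bearing core

The source may report more compounds than this note shows. Statements on the series, on what has been measured and on what is new or still open speak of the compounds shown alone.

The account follows a series built on one shared core. Compound 1 `O=C(CCSc1nnc(-c2ccncc2)s1)NCc1ccccc1` carries a benzyl group on an amide-type nitrogen; in an ADME assay on BHK-21 cells (Mesocricetus auratus) for cytotoxicity, with a stated time of 3 days (a lower number here means that less compound is tolerated, a higher number that more compound is tolerated), compound 1 gives 18700 nM. Compound 2 `S=c1[nH]nc(-c2ccncc2)s1` is the bare core, and in this assay compound 2 gives 14700 nM. Compound 1 therefore shows the higher of the two reported numbers, but its distance to compound 2 lies within the scatter, so the two cannot be ordered. Compound 3 `O=C(CSc1nnc(-c2ccncc2)s1)Nc1c(Cl)cccc1Cl` carries a 2,6-dichlorophenyl group on a shorter chain, and in this assay compound 3 is recorded as "not determined" (no result reported), so no number is available for it. The unmeasured compound 4 `O=C(CCSc1nnc(-c2ccncc2)s1)Nc1c(Cl)cccc1Cl` differs from compound 1 in one place: 2,6-dichlorophenyl in place of benzyl on an amide-type nitrogen. For the measured compounds named here, no measured pair in the set traces this exact change, so the expectation rests on the narrow spread between compound 1 and compound 2 alone. Compound 4 is expected to tolerate a somewhat lower concentration, a step of a 1.6-fold lower number from compound 1 to compound 4 (0.19 log units; within the scatter) that may not exceed the scatter. Compound 4 is thus estimated at 12000 nM, within a range from 5000 nM to 30000 nM.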

Compound 4, half-maximal cytotoxic concentration: 10300 nM
Estimate against measurement, compound 4: 1.2-fold (0.07 log units) above; the range from low to high includes it.
By their numbers in this assay, from the lowest: compounds 4, 2 and 1 (each within the scatter of the next).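

In this assay, for the compounds shown here, 2,6-dichlorophenyl in place of benzyl on the amide-type nitrogen gives the first step between compounds that differ in one place (a 1.8-fold lower number from compound 1 to compound 4 (0.26 log units; within the scatter)), so the two cannot be ordered. At this position, on the chain of compound 1, the exchange of these two groups therefore leaves no change that can be told from the scatter, and this single pair cannot show whether any other group would do the same. No measured evidence bears on this result. 

From the compounds shown here alone, how an amine or a carboxylic acid on the amide-type nitrogen would read in this assay remains open. So does the outcome of a longer chain in place of the one in compound 1, and whether any change here can give a step beyond the scatter.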